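This account rests on a few compounds, and the source may have more. Where it says the series, first, only, none or still open, it means among the compounds named here.

Measured compounds in an ADME assay on THP-1 cells (Homo sapiens) for cytotoxicity, read by resazurin assay, with a stated time of 48 h; on this read-out higher numbers stand for weaker inhibition and lower numbers for stronger inhibition:

compound 1 `CN(C)c1ccc(-c2ccc(Cn3cccc(O)c3=O)cc2)cc1`: > 10 ug/mL, a limit of the assay
compound 2 `CN(C)c1ccc(-c2ccc(Cn3cccc(O)c3=S)cc2)cc1`: > 10 ug/mL, a limit of the assay
compound 3 `CN(C)c1ccc(-c2ccc(Cn3cccc(O)c3=O)cc2)cn1`: > 10 ug/mL, a limit of the assay

The change from compound 1 to compound 2 is a group of 8 heavy atoms (5 carbon, 1 nitrogen, 1 oxygen, 1 sulfur; one six-membered aromatic ring with 1 hetero atom) in place of a group of 8 heavy atoms (5 carbon, 1 nitrogen, 2 oxygen; one six-membered aromatic ring with 1 hetero atom), on a saturated chain carbon bound to an aromatic carbon. Its step is a step that the two limits leave unreadable from compound 1 to compound 2. All three values sit at the same limit, as summarised by the limit of > 10 ug/mL in this assay, at which 3 of the 3 values shown sit.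

Compound 4 `CN(C)c1ccc(-c2ccc(Cn3cccc(O)c3=S)cc2)cn1` has not been measured. It differs from compound 3 by a group of 8 heavy atoms (5 carbon, 1 nitrogen, 1 oxygen, 1 sulfur; one six-membered aromatic ring with 1 hetero atom) in place of a group of 8 heavy atoms (5 carbon, 1 nitrogen, 2 oxygen; one six-membered aromatic ring with 1 hetero atom), on a saturated chain carbon bound to an aromatic carbon, the same change at the same place as that from compound 1 to compound 2. The difference between the core of compound 1 and the core of compound 3 is not broken down here.

For the step to compound 4 the expectation is a step that the limit leaves unreadable from compound 3 to compound 4, set beside the earlier step; this rests on (the limit of > 10 ug/mL in this assay, at which 3 of the 3 values shown sit), with no measured value leaving the limit. Compound 4 is therefore expected to give 15 ug/mL in this assay, most likely again as a limit.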

Compound 4, half-maximal inhibitory concentration: > 10 ug/mL
Compound 4: only a limit was reported (the forecaster's own chance of this, stated with the estimate: 85%); the middle value lies beyond the limit too.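

No step can be read between compound 3 and compound 4, as both values are limits in this assay: the limit of > 10 ug/mL in this assay, at which 4 of the 4 values shown sit.

The compounds shown leave open whether this group exchange, on the core of compound 1 or of compound 3, changes the read-out at all.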